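This account rests on a few compounds, and the source may have more. Where it says the series, first, only, none or still open, it means among the compounds named here.

Measured so far:
- compound 1 `O=C(Nc1cccc(-n2cc(-c3ccncc3)c(-c3ccc(Cl)c(O)c3)n2)c1)Nc1ccc(Cl)c(Cl)c1` — > 32500 nM in a functional assay on OVCAR-8 cells (Homo sapiens) for inhibition, read by sulforhodamine B assay, with a stated time of 48 h; a lower number here means that less compound is tolerated, a higher number that more compound is tolerated
- compound 2 `O=C(Nc1cccc(-n2cc(-c3ccncc3)c(-c3ccc(Cl)c(O)c3)n2)c1)Nc1cc(C(F)(F)F)cc(C(F)(F)F)c1` — 43700 nM in this assay

Compound 1 stands at a limit of this assay rather than at a number: the value > 32500 nM means that no half-maximal killing was reached in the range tested, as the line the limit of > 32500 nM in this assay, at which 1 of the 2 values shown sits, records. Compound 2, which carries two trifluoromethyl groups on the outer ring of the urea, gives 43700 nM in this assay, a plain number but a very weak one. Within the data shown here, no step between two measured compounds that differ in one place is available here, so the two values can only be set side by side.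

Compound 3 `O=C(Nc1cccc(-n2cc(-c3ccncc3)c(-c3ccc(Cl)c(O)c3)n2)c1)Nc1ccc(Cl)c(C(F)(F)F)c1` has not yet been measured in this assay. It differs from compound 1 in one place: trifluoromethyl in place of chloro on an aromatic carbon. That is the same kind of exchange that separates compound 1 from compound 2, made once instead of twice. Compound 1 sits at a limit of this assay, > 32500 nM. Compound 2 gives a plain number, 43700 nM. On that basis no step beyond the usual scatter is expected for compound 3. The step that the limit leaves unreadable from compound 1 to compound 3 is therefore expected to be small, and a limit is about as likely as a number. Compound 3 is estimated to give 40000 nM, between 15000 nM and 100000 nM.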

Compound 3, concentration lethal to 50% of the cells: > 32500 nM
Compound 3: a limit, no number; the forecaster's own chance of this, stated with the estimate: 50%; the middle value is on the limit's open side.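

In this assay compound 3 gives > 32500 nM, a limit and not a number. Compound 1 also stands at a limit, so no step from compound 1 to compound 3 can be read: the limit of > 32500 nM in this assay, at which 2 of the 3 values shown sit.

The compounds shown leave open whether trifluoromethyl in place of chloro changes the result in this assay at all.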